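The source may report more compounds than this note shows. Statements on the series, on what has been measured and on what is new or still open speak of the compounds shown alone.

Measured in a functional assay on MIA PaCa-2 cells (Homo sapiens) for inhibition, read by MTT assay, with a stated time of 72 h; a lower number here means a stronger inhibitor, a higher number a weaker inhibitor:
Compound 1 `COc1cc(NC(C)CCCNC(=O)Nc2cccc(Cl)c2)c2ncccc2c1`: 21000 nM
Compound 2 `COc1cc(NC(C)CCCNC(=O)Nc2cccc(C(F)(F)F)c2)c2ncccc2c1`: 17000 nM
Compound 3 `COc1cc(NC(C)CCCNC(=O)Nc2ccc(Cl)cc2)c2ncccc2c1`: 22000 nM

Compound 3 does not stand apart from the other two compounds. The comparisons show a 1.0-fold higher number from compound 1 to compound 3 (0.02 log units; within the scatter) and a 1.3-fold higher number from compound 2 to compound 3 (0.11 log units; within the scatter), and both steps lie within the scatter.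

The next compound is compound 4 `COc1cc(NC(C)CCCNC(=O)NNC(=O)Nc2cccc(Cl)c2)c2ncccc2c1`, and its difference from compound 3 is ((3-chlorophenyl)carbamoyl)amino in place of 4-chlorophenyl on an amide-type nitrogen. In words, ((3-chlorophenyl)carbamoyl)amino takes the place of 4-chlorophenyl on an amide-type nitrogen whose other neighbour is a carbonyl carbon.

Within the data shown here, no measured step makes a change of this kind, so the evidence is only indirect. The nearest guides are changes to the aromatic group. Trifluoromethyl in place of chloro gave a 1.2-fold lower number from compound 1 to compound 2 (0.09 log units; within the scatter), and 4-chlorophenyl in place of 3-chlorophenyl gave a 1.0-fold higher number from compound 1 to compound 3 (0.02 log units; within the scatter). Neither step goes beyond the scatter, and compound 4 carries the 3-chlorophenyl group of compound 1, which gives 21000 nM.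

In this assay, among the measured compounds shown here, the likeliest expectation is therefore no step beyond the scatter, although the uncertainty is wide because no measured compound carries the entering group. The expected change is a 1.5-fold lower number from compound 3 to compound 4 (0.17 log units; within the scatter). The estimated value for compound 4 is 15000 nM, with an expected range of 4000 nM to 50000 nM.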

Compound 4, half-maximal inhibitory concentration: 74000 nM
Beside the measured number, compound 4's estimate is 4.9-fold (0.69 log units) below it, and the stated range ends below it.
By their numbers in this assay, from the lowest: compounds 2, 1 and 3 (each within the scatter of the next); then compound 4.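

Until now, changes to the aromatic group on this amide-type nitrogen had moved nothing beyond the scatter in this assay, but ((3-chlorophenyl)carbamoyl)amino does, giving a 3.5-fold higher number from compound 1 to compound 4 (0.55 log units; beyond the scatter). Compound 4 keeps the 3-chlorophenyl group of compound 1, so this step comes from the carbamoyl-amino link that now carries the ring rather than from a new ring, and the weaker result also holds against the other two compounds, with a 3.4-fold higher number from compound 3 to compound 4 (0.53 log units; beyond the scatter) and a 4.4-fold higher number from compound 2 to compound 4 (0.64 log units; beyond the scatter). Nothing in the data shown gives a reason for this weakening.

Among these compounds, compound 4 is the only compound with this link, so it remains open whether the same step would appear with the 4-chlorophenyl or 3-(trifluoromethyl)phenyl group at its end. As far as these compounds go, it is also open how a plain amino group or a longer carbon chain would behave as the link on this nitrogen, which would help show whether the length of the link or its carbonyl matters more.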